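Swapping Ethyl for Fluoro on the Outer Phenyl Ring

This account rests on a few compounds, and the source may have more. Where it says the series, first, only, none or still open, it means among the compounds named here.

Compound 1 `CCc1ccc(-c2ccc(NC3=CC(=O)c4ncncc4C3=O)cc2)cc1` carries a 4-ethylphenyl group on the shared core, and in a functional assay on MIA PaCa-2 cells (Homo sapiens) for cytotoxicity, read by MTT assay, with a stated time of 72 h (a lower number here means a stronger inhibitor, a higher number a weaker inhibitor), compound 1 gives 2000 nM, the lowest of the three numbers in hand. Compound 2 `Cc1ccc(-c2ccc(NC3=CC(=O)c4ncncc4C3=O)cc2F)cc1` gives 4600 nM in this assay, a step beyond the scatter from compound 1, while the bare core, compound 3 `O=C1C=CC(=O)c2ncncc21`, gives 9400 nM, the furthest from compound 1. Compound 4 `O=C1C(Nc2ccc(-c3ccc(F)cc3)cc2)=CC(=O)c2ncncc21` has not yet been measured; it differs from compound 1 by fluoro in place of ethyl on an aromatic carbon, so 4-ethylphenyl becomes 4-fluorophenyl. For the measured compounds named here, no measured pair isolates this change. The step is expected to be small, toward a higher number and near the edge of the scatter: a 1.8-fold higher number from compound 1 to compound 4 (0.24 log units; within the scatter). Compound 4 is therefore estimated at 3500 nM, within a range of 1500 nM to 8000 nM.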

Compound 4, half-maximal inhibitory concentration: 3500 nM
Compound 4: middle estimate and measured number agree at the digits printed, within the range that was stated.
By their numbers in this assay, from the lowest: compounds 1, 4 and 2 (each within the scatter of the next, the first and the last beyond it); then compound 3.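

For the compounds shown here, the pair gives the first direct reading at this position: fluoro in place of ethyl on the outer ring is a 1.8-fold higher number from compound 1 to compound 4 (0.24 log units; within the scatter) in this assay. At this place, para to a large group, 4-ethylphenyl and 4-fluorophenyl therefore cannot be told apart in this read-out. No measurement bears on why the two groups read alike.

As far as these compounds go, whether an amine, a carboxylic acid or a longer chain at this position would move the number beyond the scatter remains open.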